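Cytotoxicity Limits Across a Shared-Core Series

The compounds below may be only part of what the source reports. "The series", "measured", "known", "first", "only" and "open" are said of these compounds alone.

Compound 2 `Cc1nc(C)c([C@H](OC(C)(C)C)C(=O)O)c(N2CCC(C)(C)CC2)c1-c1ccc(Cc2ccccc2)cc1` carries a benzyl group on an aromatic carbon of the shared core. In a toxicity assay on MT2 cells (Homo sapiens) for cytotoxicity, read by XTT assay, with a stated time of 4 days (on this read-out higher numbers stand for lower toxicity in this test and lower numbers for higher toxicity in this test), compound 2 gives >= 20000 nM, which is a limit of the assay and not a number. Compound 1 `Cc1nc(C)c([C@H](OC(C)(C)C)C(=O)O)c(N2CCC(C)(C)CC2)c1-c1ccc(-c2ccccc2)cc1` bears phenyl at that place; in this assay compound 1 gives >= 20000 nM, likewise a limit. Compound 3 `Cc1ccc(CCOc2ccc(-c3c(C)nc(C)c([C@H](OC(C)(C)C)C(=O)O)c3N3CCC(C)(C)CC3)cc2)cc1` bears 2-(4-methylphenyl)ethoxy there, and in this assay compound 3 gives >= 33500 nM, again a limit. Compound 2 thus stands with only a limit, and the two other values shown are limits as well, two of the three sitting at the limit of >= 20000 nM in this assay, at which 2 of the 3 values shown sit, and one at the limit of >= 33500 nM in this assay, at which 1 of the 3 values shown sits.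

The unmeasured compound 4 `Cc1nc(C)c([C@H](OC(C)(C)C)C(=O)O)c(N2CCC(C)(C)CC2)c1-c1ccc(OCCc2ccc(F)c(F)c2)cc1` differs from compound 2 as follows: 2-(3,4-difluorophenyl)ethoxy in place of benzyl on an aromatic carbon. For the measured compounds named here, the steps that bear on this change are a step that the two limits leave unreadable from compound 1 to compound 2, a step that the two limits leave unreadable from compound 2 to compound 3 and a step that the two limits leave unreadable from compound 1 to compound 3; none has a readable size, so no direction can be drawn from them. The closest of them, a step that the two limits leave unreadable from compound 2 to compound 3, brings a 2-(4-methylphenyl)ethoxy group into the same place and stays within the limits. No step beyond the scatter is therefore expected in this assay. Compound 4 is expected to give 30000 nM (range 15000 nM to 60000 nM) in this assay, most likely reported as a limit. The step this estimate means, a step that the limit leaves unreadable from compound 2 to compound 4, is expected to lie within the scatter.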

Compound 4, half-maximal cytotoxic concentration: >= 33500 nM
Compound 4: no number, only a limit; the forecaster's own chance of this, stated with the estimate: 85%; middle value at least 1.1-fold (0.04 log units) from the limit.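

In this assay compound 4 gives >= 33500 nM, which is a limit of the assay and not a number. None of the steps from compound 1, compound 2 or compound 3 to compound 4 can be read. The compounds shown leave open whether changing the group at this place alters the read-out in this assay at all.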